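A few compounds are considered here, and "the series" means these few. Any claim that something is new, unique, unknown or untested is made for them only; others in the source may bear on it.

Measured so far in a functional assay on B16 cells (Mus musculus) for cytotoxicity, read by MTT assay, with a stated time of 48 h; on this read-out higher numbers stand for weaker inhibition and lower numbers for stronger inhibition:
compound 1 `Cc1ccc(-c2cn(Cc3ccccc3)nn2)cc1` — > 100000 nM
compound 2 `COc1ccc(-c2cn(Cc3ccccc3)nn2)cc1` — > 100000 nM
compound 3 `COc1ccc(C(O)c2cn(Cc3cccc(OC)c3)nn2)cc1` — > 100000 nM

Each of these three values is a limit of the assay, not a number: the limit of > 100000 nM in this assay, at which 3 of the 3 values shown sit. For compound 3 in this assay only this limit is known, and the same holds for the two other compounds. From compound 2 to compound 1 the change is methyl in place of methoxy on an aromatic carbon, and the step that the two limits leave unreadable from compound 2 to compound 1 cannot be read, since both ends are limits. The difference between the cores of compound 3 and compound 2 is not broken down here.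

Compound 4 `COc1cccc(Cn2cc(C(O)c3ccc(C)cc3)nn2)c1` is not yet measured. It arises from compound 3 by methyl in place of methoxy on an aromatic carbon, the same change as from compound 2 to compound 1. Since that earlier step left both compounds at the limit, the step that the limit leaves unreadable from compound 3 to compound 4 is expected to be small, and compound 4 is estimated at 200000 nM, most likely again a limit.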

Compound 4, half-maximal inhibitory concentration: > 100000 nM
Compound 4 ended at the assay's limit (the forecaster's own chance of this, stated with the estimate: 85%); the middle value does not contradict the limit.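

In this assay no step can be read from compound 3 to compound 4, as both ends are limits: the limit of > 100000 nM in this assay, at which 4 of the 4 values shown sit.

The compounds shown leave open which change to these structures, if any, would give a readable value in this assay at all.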